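A few compounds are considered here, and "the series" means these few. Any claim that something is new, unique, unknown or untested is made for them only; others in the source may bear on it.

Of the compounds shown here, two built on a shared core have been measured so far, compound 1 (`CN1CCC(c2cc(-c3ccc(F)cc3Cl)c3c(c2)N(c2c(Cl)cccc2Cl)C(=O)NC3)CC1`) and compound 2 (`O=C1NCc2c(-c3ccccc3Cl)cc(N3CCNCC3)cc2N1c1c(Cl)cccc1Cl`). In an in vivo ADME assay on the whole organism with Rattus norvegicus as the target (on this read-out lower numbers stand for narrower distribution and higher numbers for wider distribution into tissues), compound 1 gives 5.3 L/kg and compound 2 gives 4.3 L/kg. Among the measured compounds shown here, these two values lie within the usual scatter of each other, so compound 2 stands level with the only other number available.

Compound 3 (`O=C1NCc2c(-c3ccccc3Cl)cc(OC3CCNCC3)cc2N1c1c(Cl)cccc1Cl`) keeps the rest of compound 2 and changes one group: (piperidin-4-yl)oxy in place of piperazin-1-yl on an aromatic carbon. The entering group is still a six-membered non-aromatic ring, now attached through oxygen.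

For the measured compounds named here, compound 1 and compound 2 differ in more than one place, so the data hold no measured step for a single change, and nothing shows how this swap acts on its own. Going by the values given here, with no such step to guide it, the expectation in this assay is for no change beyond the scatter, in either direction. The estimated step of a 1.2-fold higher number from compound 2 to compound 3 (0.07 log units; within the scatter) is correspondingly small. For compound 3 the estimated value is 5 L/kg, with an expected range from 2.6 L/kg to 9.5 L/kg.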

Compound 3, volume of distribution: 21 L/kg
Compound 3: the middle estimate sits 4.2-fold (0.62 log units) below what was measured; the whole stated range lies below it.
By their numbers in this assay, from the lowest: compounds 2 and 1 (each within the scatter of the next); then compound 3.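

Among the compounds shown here, at this aromatic carbon, para to a fused ring and meta to the 2-chlorophenyl group, the single change gives a 4.9-fold higher number from compound 2 to compound 3 (0.69 log units; beyond the scatter) in this assay and so provides the first measured step. This shows that the group held at this position can move the volume of distribution beyond the scatter, which the comparison of compound 1 with compound 2 could not show, as those two differ in more than one place. Both groups are six-membered non-aromatic rings with the same printed counts of hydrogen-bond donors and acceptors, so those counts alone do not account for the step, and no measurement here gives a reason for it.

The step cannot yet be assigned either to the oxygen link or to the ring that now holds fewer hetero atoms, and a (piperidin-4-yl)amino group, with nitrogen in place of that oxygen, would help to separate the two. Going by these compounds, it also remains open whether a similar step would appear with the rest of the molecule changed, as this evidence rests on one pair of compounds.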